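Propyl for Phenyl on the Amide Nitrogen

The compounds below may be only part of what the source reports. "The series", "measured", "known", "first", "only" and "open" are said of these compounds alone.

Compound 3 `C=CC1=C(C(=O)Nc2ccccc2)C(c2ccc(OC)cc2)OC1` stands at the limit of a functional assay on HeLa cells (Homo sapiens) for cytotoxicity, read by MTT assay, with a stated time of 24 h; a lower number here means a stronger inhibitor, a higher number a weaker inhibitor: the value recorded for compound 3, > 100000 nM, is a limit of the assay and not a number. Compound 1 `C=CC1=C(C(=O)NCCCCC)C(c2ccc(OC)cc2)OC1` likewise reaches only a limit in this assay, > 100000 nM. Compound 2 `C=CC1=C(C(=O)NCCC)C(c2ccc(F)cc2)OC1` gives > 100000 nM in this assay, again a limit. Among the compounds with values here, the single measured step, a step that the two limits leave unreadable from compound 1 to compound 3, cannot be read, since every value shown sits at the same limit (the limit of > 100000 nM in this assay, at which 3 of the 3 values shown sit). Compound 4 `C=CC1=C(C(=O)NCCC)C(c2ccc(OC)cc2)OC1` differs from compound 3 by propyl in place of phenyl on an amide-type nitrogen. Within the data shown here, no measured step gives this change a size in this assay, so no shift beyond the scatter is expected. Compound 4 is expected to remain at the limit, the step being a step that the limit leaves unreadable from compound 3 to compound 4. Compound 4 is therefore estimated at 150000 nM, within 60000 nM to 400000 nM.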

Compound 4, half-maximal inhibitory concentration: 14000 nM
Compound 4: the middle estimate sits 11-fold (1.03 log units) above what was measured; the whole stated range lies above it.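

In this assay, the amide nitrogen proves able to move the read-out, with propyl in place of phenyl giving an at least 7.1-fold lower number from compound 3 to compound 4 (0.85 log units; beyond the scatter). The effect depends on more than the presence of an alkyl chain: the shorter propyl chain gives an at least 7.1-fold lower number from compound 1 to compound 4 (0.85 log units; beyond the scatter), and methoxy in place of fluoro on the aromatic carbon gives an at least 7.1-fold lower number from compound 2 to compound 4 (0.85 log units; beyond the scatter). Compound 4 alone comes off the limit: the limit of > 100000 nM in this assay, at which 3 of the 4 values shown sit.

Going by these compounds, the full size of each step remains open, since each is measured against a limit. Also open, on these data alone, is how an ethyl chain, or a propyl chain ending in an amine or a carboxylic acid, would behave on this nitrogen.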